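The source may report more compounds than this note shows. Statements on the series, on what has been measured and on what is new or still open speak of the compounds shown alone.

Measured in a functional assay on BXPC-3 cells (Homo sapiens) for antiproliferative activity, read by MTT assay, with a stated time of 24 h; on this read-out higher numbers stand for weaker inhibition and lower numbers for stronger inhibition:
- Compound 1 `CCn1c(C(=O)N[C@H](C)C(=O)OC)ccc1C(CC)(CC)c1ccc(OCS(=O)(=O)c2ccccc2)c(C)c1`: > 50000 nM, a limit and not a number
- Compound 2 `CCn1c(C(=O)NCCO)ccc1C(CC)(CC)c1ccc(OCS(=O)(=O)c2ccccc2)c(C)c1`: 19900 nM
- Compound 3 `CCn1c(C(=O)N[C@H](C)CO)ccc1C(CC)(CC)c1ccc(OCS(=O)(=O)c2ccccc2)c(C)c1`: 10000 nM

Only compound 2 and compound 3 have true numbers, and these two lie within the scatter of each other. Compound 4 `CCn1c(C(=O)N[C@@H](CO)C(C)C)ccc1C(CC)(CC)c1ccc(OCS(=O)(=O)c2ccccc2)c(C)c1` carries isopropyl in place of methyl on a saturated chain carbon bound to an amide-type nitrogen and a saturated chain carbon. The closest guide is methyl in place of hydrogen at that same carbon, a 2.0-fold lower number from compound 2 to compound 3 (0.30 log units; within the scatter). Among the compounds with values here, the hydroxymethyl group stays, so the larger change, an at least 5.0-fold lower number from compound 1 to compound 3 (0.69 log units; beyond the scatter), offers no guide to this step. No change beyond the scatter is therefore expected in this assay, and the estimated step is a 1.3-fold lower number from compound 3 to compound 4 (0.10 log units; within the scatter). For compound 4 the expected value is 8000 nM, with an estimated range of 3000 nM to 25000 nM.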

Compound 4, half-maximal inhibitory concentration: 13200 nM
Compound 4: the middle estimate sits 1.7-fold (0.22 log units) below what was measured; low and high end bracket the measured number.
By their numbers in this assay, from the lowest: compounds 3, 4 and 2 (each within the scatter of the next). At a limit, above all of these: compound 1.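

In this assay, isopropyl on this saturated chain carbon gives a 1.3-fold higher number from compound 3 to compound 4 (0.12 log units; within the scatter), and in place of hydrogen it gives a 1.5-fold lower number from compound 2 to compound 4 (0.18 log units; within the scatter), so a group of 3 carbons here brings no change beyond the scatter. Replacing the whole 1-(methoxycarbonyl)ethyl group with 1-(hydroxymethyl)-2-methylpropyl gives an at least 3.7-fold lower number from compound 1 to compound 4 (0.57 log units; beyond the scatter), so the difference seen with the smaller hydroxymethyl compounds remains with isopropyl. Compound 1 has a limit, not a true number: the limit of > 50000 nM in this assay, at which 1 of the 4 values shown sits.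

Still open, as far as these compounds go, is how a phenyl ring or an amine on this carbon would read. A carboxylic acid in place of hydroxymethyl is also untested among the compounds shown.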